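The compounds below may be only part of what the source reports. "The series", "measured", "known", "first", "only" and "open" are said of these compounds alone.

Compound 1 `COc1ccc2[nH]c(-c3cn(-c4ccccc4)nc3-c3ccc(Cl)cc3)nc2c1`: 2420 nM
Compound 2 `COc1ccc(-c2nn(-c3ccccc3)cc2-c2nc3cc(Cl)ccc3[nH]2)cc1`: 3130 nM

These two compounds have been tested in a functional assay on A549 cells (Homo sapiens) for antiproliferative activity, read by MTT assay, with a stated time of 48 h; on this read-out lower numbers stand for stronger inhibition and higher numbers for weaker inhibition. Compound 2 gives 3130 nM, which lies within the usual scatter of repeated measurements from compound 1 at 2420 nM. Within the data shown here, the two numbers therefore cannot be told apart, and compound 2 stands level with the only other compound measured so far.

The next compound, compound 3 `COc1ccc(-c2nn(-c3ccccc3)cc2-c2nc3cc(OC)ccc3[nH]2)cc1`, differs from compound 2 in one place: it has methoxy in place of chloro on an aromatic carbon. That carbon belongs to a six-membered aromatic ring of carbon only, part of a fused system of two rings.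

Among the measured compounds shown here, no measured pair isolates this exact change, so its size cannot be read directly from the data. For the measured compounds named here, the only guide is the closeness of the two known values, so no step beyond the scatter is expected in this assay, in either direction. The range must stay wide, since it rests on so little.

For compound 3 the estimated value is 3000 nM, with an expected range from 1200 nM to 7500 nM. This estimate amounts to an expected 1.0-fold lower number from compound 2 to compound 3 (0.02 log units; within the scatter).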

Compound 3, half-maximal inhibitory concentration: 22700 nM
Compound 3: middle estimate off by 7.6-fold (0.88 log units), on the low side; the measured number lies above the stated range.
By their numbers in this assay, from the lowest: compounds 1 and 2 (each within the scatter of the next); then compound 3.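

In this assay, putting methoxy in place of chloro on this carbon of the fused system is not a neutral swap: the change gives a 7.3-fold higher number from compound 2 to compound 3 (0.86 log units; beyond the scatter), so this position is sensitive to the group it carries. The same exchange on a different aromatic carbon, outside the fused system, gives a 9.4-fold higher number from compound 1 to compound 3 (0.97 log units; beyond the scatter), so both single changes that remove the only chloro lead to weaker inhibition in compound 3. No measurement shown here explains why these changes weaken inhibition.

On these data alone, with only these two groups compared, it remains open whether the loss comes from chloro leaving or from methoxy entering. A hydrogen, a fluoro, a methyl or an amine on the same carbon of the fused system could help separate those two possibilities and show how much room this position allows.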